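The source may report more compounds than this note shows. Statements on the series, on what has been measured and on what is new or still open speak of the compounds shown alone.

The measured compounds:

Compound 1, `CCOC(=O)CNC(=O)N1CC1C#N`, gives 11000 nM in a functional assay on MCF7 cells (Homo sapiens) for inhibition; a lower number here means a stronger inhibitor, a higher number a weaker inhibitor.
Compound 2, `N#CC1CN1C(=O)Nc1ccc(F)cc1`, gives 2700 nM in this assay.
Compound 3, `CCOC(=O)c1ccc(NC(=O)N2CC2C#N)cc1`, gives 3300 nM in this assay.

Compound 3 stands second highest of the three numbers in this assay. Its nearest neighbour is compound 2, whose number sits within the scatter of it; the furthest is compound 1, whose number lies beyond the scatter above it.

Compound 4 is `N#CC1CN1C(=O)Nc1ccccc1`. It differs from compound 3 by hydrogen in place of ethoxycarbonyl on an aromatic carbon. For the measured compounds named here, the one measured step that bears on this change is the exchange of the group at the same place on the ring, a 1.2-fold higher number from compound 2 to compound 3 (0.09 log units; within the scatter), which stayed within the scatter. Since swapping fluoro for ethoxycarbonyl at that place did not move the number beyond the scatter, removing the ethoxycarbonyl altogether is expected to leave the number close to that of compound 3, with a step of a 1.1-fold lower number from compound 3 to compound 4 (0.04 log units; within the scatter). Compound 4 is therefore estimated at 3000 nM, within a range from 1200 nM to 7500 nM.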

Compound 4, half-maximal inhibitory concentration: 4300 nM
Compound 4: middle estimate off by 1.4-fold (0.16 log units), on the low side, and the stated range covers the measured number.
By their numbers in this assay, from the lowest: compounds 2, 3 and 4 (each within the scatter of the next); then compound 1.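

For the compounds shown here, compound 4 carries only hydrogen on this aromatic carbon, which gives the earlier compounds a comparison they lacked. In this assay, hydrogen in place of ethoxycarbonyl gives a 1.3-fold higher number from compound 3 to compound 4 (0.11 log units; within the scatter), and hydrogen in place of fluoro gives a 1.6-fold higher number from compound 2 to compound 4 (0.20 log units; within the scatter); both steps lie within the scatter, so hydrogen, fluoro and ethoxycarbonyl cannot be told apart here, although ethoxycarbonyl brings five heavy atoms and hydrogen none. Nothing available explains this result.

Going by these compounds, whether an amine, a carboxylic acid or a longer chain on this aromatic carbon would move the number beyond the scatter remains open. On these data alone, the role of the aromatic ring also remains open, since compound 1 differs from these three compounds in more than one place.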